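Heteroaryl amides in a free fatty acid receptor 2 series

The source may report more compounds than this note shows. Statements on the series, on what has been measured and on what is new or still open speak of the compounds shown alone.

The account begins with compound 1 `CC(C)[C@H](C(=O)NCc1ccccc1)c1ccc(Cl)cc1`. In a functional assay on CHO cells for agonist activity at Free fatty acid receptor 2 (Homo sapiens), read by cAMP accumulation (on this read-out higher numbers stand for weaker inhibition and lower numbers for stronger inhibition), compound 1 reaches only the assay limit, > 100000 nM, which is a limit and not a number (the limit of > 100000 nM in this assay, at which 1 of the 2 values shown sits). A related amide, compound 2 `CC(C)C(C(=O)Nc1ncccn1)c1ccc(Cl)cc1`, gives 53000 nM in this assay. Compound 3 `CC(C)[C@H](C(=O)Nc1ncc(C#N)s1)c1ccc(Cl)cc1` carries 5-cyano-1,3-thiazol-2-yl in place of benzyl on an amide-type nitrogen. Among the compounds with values here, no measured step links these compounds, so compound 3 is estimated to move in the direction of stronger inhibition, an at least 20-fold lower number from compound 1 to compound 3 (1.30 log units; beyond the scatter), a step expected beyond the scatter. Compound 3 is expected to give about 5000 nM, within 500 nM to 50000 nM.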

Compound 3, half-maximal inhibitory concentration: 2000 nM
Compound 3: middle estimate off by 2.5-fold (0.40 log units), on the high side, within the range that was stated.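

Putting 5-cyano-1,3-thiazol-2-yl in place of benzyl on the amide-type nitrogen gives, in this assay, an at least 50-fold lower number from compound 1 to compound 3 (1.69 log units; beyond the scatter). Within the data shown here, this is the first measured step, and it shows that the group on this nitrogen can move the read-out well beyond the scatter. The value of compound 1 is a limit and not a number: the limit of > 100000 nM in this assay, at which 1 of the 3 values shown sits.

The compounds shown do not separate the share of the five-membered aromatic ring from that of its nitrile. On these data alone, how a carboxylic acid or a methyl group in place of that nitrile would read remains open.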